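Adding a Second Methoxy Group: An Expected Cytotoxicity Value

The source may hold more compounds than are shown below. What is called first, only, known or untested is meant among the compounds shown, and "the series" means these compounds.

Compound 1 `O=C(CCCCC1CCSS1)NCc1cn(CCCOc2ccc3cc(-c4ccccc4)c(=O)oc3c2)nn1`: in a functional assay on PC-12 cells (Rattus norvegicus) for cytotoxicity, read by MTT assay, with stated times of 3 h and 2 h, tested at 5 uM (a higher number here means a stronger effect of the compound at the concentration tested, a lower number a weaker effect), compound 1 gives 29.8%.
Compound 2 `COc1ccc(-c2cc3ccc(OCCCn4cc(CNC(=O)CCCCC5CCSS5)nn4)cc3oc2=O)cc1`: compound 2 gives 52.8%.
Compound 3 `COc1ccc(-c2cc3ccc(OCCCCCn4cc(CNC(=O)CCCCC5CCSS5)nn4)cc3oc2=O)cc1`: compound 3 gives 41%.

Compound 2 differs from compound 1 by one change, (methoxy in place of hydrogen on an aromatic carbon), and that single change brought a step of a number 23 percentage points higher from compound 1 to compound 2 (beyond the scatter). Compound 3 differs from compound 1 in more than one place; the difference between the two cores is not broken down here. Compound 3 stands between the other two in this assay, with compound 1 lower and compound 2 higher.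

Compound 4 `COc1ccc(-c2cc3ccc(OCCCCCn4cc(CNC(=O)CCCCC5CCSS5)nn4)cc3oc2=O)cc1OC` has not yet been measured. It differs from compound 3 by methoxy in place of hydrogen on an aromatic carbon. This is the same kind of change as from compound 1 to compound 2, but not the same one: in compound 2 the entering methoxy sits para to a large group, whereas in compound 4 it sits ortho to a methoxy group and meta to a large group. Among the compounds with values here, only one measured step of this kind exists, and it was taken on a ring without any methoxy group, so a smaller step is expected here than a number 23 percentage points higher from compound 1 to compound 2 (beyond the scatter). Compound 4 is expected to give about 50% in this assay, with a likely range from 35% to 65%. The estimated step is a number 9 percentage points higher from compound 3 to compound 4 (within the scatter).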

Compound 4, a percentage reported as activity, at one concentration (the size of the read-out at that concentration, not a potency): 46.9%
Beside the measured number, compound 4's estimate is 3.1 percentage points above it; measured number inside the range.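

In this assay, the entering methoxy on the 4-methoxyphenyl group of compound 3 gave a number 5.9 percentage points higher from compound 3 to compound 4 (within the scatter). The same kind of change therefore did not carry over from one core to the other with the same size: the same change on two cores in this assay, a number 23 percentage points higher (beyond the scatter) from compound 1 to compound 2 and a number 5.9 percentage points higher (within the scatter) from compound 3 to compound 4, 17.1 percentage points apart, beyond the scatter of two such steps. This shows that a step seen on one core in this series cannot simply be transferred to another, but it does not show what sets the size of the step, as the two pairs differ both in the length of the chain and in whether a methoxy group already sits on the ring, and the data do not separate the two.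

The compounds shown leave open what the 3,4-dimethoxyphenyl group would give on the core of compound 1, which would separate the chain from the ring substitution. They also leave open how a hydroxy group, an amine or a carboxylic acid at the same ring position would read in this assay.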